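Furan swap on the cyanoacrylamide: compound 2 to compound 4

This account rests on a few compounds, and the source may have more. Where it says the series, first, only, none or still open, it means among the compounds named here.

Measured compounds:
compound 1 `N#C/C(=C\c1c(F)c(F)c(F)c(F)c1F)C(=O)c1ccc[nH]1`, > 100000 nM
compound 2 `COc1ccc(CNC(=O)/C(C#N)=C/c2ccc(C)o2)cc1`, 69000 nM
compound 3 `COc1ccc(CNC(=O)/C(C#N)=C/c2ccc(-c3ccccc3)o2)cc1`, > 100000 nM

Among the measured compounds shown here, in a functional assay on SMA cells (Homo sapiens) for inhibition, read by MTT assay, with a stated time of 72 h (a lower number here means a stronger inhibitor of growth, a higher number a weaker inhibitor of growth), compound 2 gives 69000 nM, the only number among the three results. For compound 1 the value > 100000 nM is a limit of the assay, not a number. For compound 3 the value > 100000 nM is likewise a limit. For the measured compounds named here, two of the three results therefore sit at the limit of > 100000 nM in this assay, at which 2 of the 3 values shown sit, and compound 2 stands alone as the one measured number.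

Going by the values given here, the step of an at least 1.4-fold higher number from compound 2 to compound 3 (0.16 log units; that floor lies within the scatter) is the only measured step, and its floor lies within the scatter. Compound 4 `COc1ccc(CNC(=O)/C(C#N)=C/c2ccoc2)cc1` differs from compound 2 by furan-3-yl in place of 5-methylfuran-2-yl on a double-bonded chain carbon bound to a double-bonded chain carbon. Among the compounds with values here, no measured step tests this change; the step to compound 3 touches the same furan but replaces a different group. With no evidence for a shift, compound 4 is expected to stay close to compound 2 in this assay, a step of a 1.3-fold higher number from compound 2 to compound 4 (0.12 log units; within the scatter) that lies within the scatter. Compound 4 is accordingly estimated at 90000 nM, between 35000 nM and 250000 nM, with a real chance that only a limit is reported.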

Compound 4, concentration for 50% growth inhibition: 7000 nM
Beside the measured number, compound 4's estimate is 13-fold (1.11 log units) above it; the measured number lies below the stated range.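

The group on the double-bonded chain carbon matters in this assay: furan-3-yl in place of 5-methylfuran-2-yl gives a 9.9-fold lower number from compound 2 to compound 4 (0.99 log units; beyond the scatter). The earlier step at this furan, from methyl to phenyl, had a floor within the scatter, so it showed no clear response at this site, whereas this change does. Compound 4 also gives the set a second measured number, set against results that are limits and not numbers: the limit of > 100000 nM in this assay, at which 2 of the 4 values shown sit.

The compounds shown leave open whether the step follows from the loss of the methyl, from the change from a furan-2-yl to a furan-3-yl group, or from both, since the two differences arrive together. They also leave open how an unsubstituted furan-2-yl group, or a thiophene ring in the same place, would read in this assay.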